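The source may report more compounds than this note shows. Statements on the series, on what has been measured and on what is new or still open speak of the compounds shown alone.

In a functional assay, with a stated time of 30 min (a lower number here means that less compound is needed, a higher number that more compound is needed for the effect), compound 1 (`CCOC(=O)/C=C(/C(=O)OC)[C@H]1c2c(cc(O)c(O)c2O)C(=O)O[C@@H]1C(=O)OCC`) gives 6000 nM as its half-maximal effective concentration. Compound 2 (`CCOC(=O)/C=C(/C(=O)OCC)[C@H]1c2c(cc(O)c(O)c2O)C(=O)O[C@@H]1C(=O)O`) gives 5400 nM in this assay and compound 3 (`CCOC(=O)/C(=C/C(=O)O)[C@H]1c2c(cc(O)c(O)c2O)C(=O)O[C@@H]1C(=O)OCC`) gives 10800 nM on the same read-out. Compound 1 stands within the usual scatter of both, so these numbers do not set it apart from either one.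

Compound 4 (`CCOC(=O)/C=C(/C(=O)O)[C@H]1c2c(cc(O)c(O)c2O)C(=O)O[C@@H]1C(=O)OCC`) has not yet been measured. It departs from compound 1 in a single place (hydrogen in place of methyl on an oxygen next to a carbonyl group) with hydrogen in place of methyl on an oxygen next to a carbonyl group, which turns a methoxycarbonyl into a carboxy. Within the data shown here, no measured pair shows this change on its own, so the expectation rests on indirect evidence. Compound 1 has no carboxy group, while compound 2 carries one and sits at 5400 nM and compound 3 carries one elsewhere and sits at 10800 nM without leaving the scatter of compound 1. In this assay no change beyond the scatter is therefore expected, with a slight lean toward a higher number. The estimated move is a 1.3-fold higher number from compound 1 to compound 4 (0.12 log units; within the scatter) in this reading. For compound 4 the expected value is 8000 nM with an estimated range from 3500 nM to 18000 nM for repeated measurements.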

Compound 4, half-maximal effective concentration: 8100 nM
Compound 4: middle estimate off by 1.0-fold (0.01 log units), on the low side; measured number inside the range.
By their numbers in this assay, from the lowest: compounds 2, 1, 4 and 3 (each within the scatter of the next).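

In this assay, the exchange of methoxycarbonyl for carboxy now has a direct reading: hydrogen in place of methyl on an oxygen next to a carbonyl group gives a 1.4-fold higher number from compound 1 to compound 4 (0.13 log units; within the scatter). Among these compounds, until this pair, no two measured compounds differed in only one place, so this is the first step that shows a single change on its own, with the rest of the structure held constant. At this position, then, the methyl can be replaced by hydrogen without a move beyond the scatter, although this rests on one pair in one assay, and nothing available bears on why the step is this size.

The compounds shown leave open whether other groups at this position, such as a propyl ester, a primary amide or a hydroxymethyl group in place of the whole methoxycarbonyl, would also stay within the scatter of compound 1. Among the compounds shown here, they also leave open whether the same exchange of an ester alkyl group for hydrogen would read the same at the other ester positions of the shared core, since no single-change pair covers those places.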